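Swapping chloro for bromo on the benzyl ring

This account rests on a few compounds, and the source may have more. Where it says the series, first, only, none or still open, it means among the compounds named here.

Of the compounds shown here, three sharing one core have been measured in a functional assay on MGC-803 cells (Homo sapiens) for inhibition, read by sulforhodamine B assay, with a stated time of 72 h, tested at 10 uM; a lower number here means less inhibition, a higher number more inhibition at the concentration tested (going by the name of the read-out). Compound 1 `Cc1cc(Nc2ccc(C(=O)/C=C/c3cccc(Br)n3)cc2)n2nc(SCc3ccccc3)nc2n1` gives 90.2%. Compound 2 `Cc1cc(Nc2ccc(C(=O)/C=C/c3cccc(Br)n3)cc2)n2nc(SCc3ccc(F)cc3)nc2n1` gives 93.3%, and compound 3 `Cc1cc(Nc2ccc(C(=O)/C=C/c3cccc(Br)n3)cc2)n2nc(SCc3ccc(Cl)cc3)nc2n1` gives 90.2%. The step of a number 3.1 percentage points higher from compound 1 to compound 2 (within the scatter) came with fluoro in place of hydrogen on an aromatic carbon; the step of no change at the digits printed from compound 1 to compound 3 (within the scatter) came with chloro in place of hydrogen on an aromatic carbon; and the step of a number 3.1 percentage points lower from compound 2 to compound 3 (within the scatter) came with chloro in place of fluoro on an aromatic carbon. Compound 3 thus stands level with compound 1 at the digits reported, the two together the lowest of the three numbers, while its gap to compound 2 is within the scatter.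

Compound 4 `Cc1cc(Nc2ccc(C(=O)/C=C/c3cccc(Br)n3)cc2)n2nc(SCc3ccc(Br)cc3)nc2n1` has not yet been measured. It differs from compound 3 by bromo in place of chloro on an aromatic carbon. For the measured compounds named here, two measured steps bear on this change, since both end at the chloro of compound 3: no change at the digits printed from compound 1 to compound 3 (within the scatter) and a number 3.1 percentage points lower from compound 2 to compound 3 (within the scatter), each within the scatter. Every exchange among hydrogen, fluoro and chloro at this aromatic carbon left the read-out essentially where it was. Compound 4 is therefore expected to show a number 0.2 percentage points lower from compound 3 to compound 4 (within the scatter). In this assay compound 4 is estimated at 90%, with a range from 82% to 96%.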

Compound 4, a percentage reported as inhibition, at one concentration (the size of the read-out at that concentration, not a potency): 96.3%
Compound 4: the middle estimate sits 6.3 percentage points below what was measured, and the stated range ends below it.
By their numbers in this assay, from the lowest: compounds 1, 3, 2 and 4 (each within the scatter of the next).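

In this assay bromo at this aromatic carbon gives a number 6.1 percentage points higher from compound 3 to compound 4 (within the scatter) against chloro, a number 6.1 percentage points higher from compound 1 to compound 4 (within the scatter) against hydrogen and a number 3 percentage points higher from compound 2 to compound 4 (within the scatter) against fluoro. Bromo thus joins hydrogen, fluoro and chloro as a fourth substituent at this place, para to a large group, and each of its steps stays within the scatter, as the earlier steps did. The four compounds therefore cannot be ranked by this read-out, and the number for the 4-bromobenzyl compound stays within the scatter of the other three, with no measurement offered here to explain the numbers.

What the compounds shown leave open is whether the number stays within the scatter for groups of another kind on the same carbon, such as a methoxy, an amine or a carboxylic acid, or for a longer chain between the sulfur and the phenyl ring. Each number is also the size of the read-out at one concentration and not a potency, so any differences among these four compounds at lower concentrations remain unknown.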